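This account rests on a few compounds, and the source may have more. Where it says the series, first, only, none or still open, it means among the compounds named here.

Compound 3 `CCNC(=O)C1=C(C)NC(=O)NC1c1ccoc1` gives 2% in an assay on membranes from HEK293 cells for displacement of a labelled ligand from adenosine receptor A2b (Homo sapiens), read by scintillation counting, with a stated time of 30 min, tested at 1 uM; a lower number here means less inhibition, a higher number more inhibition at the concentration tested (going by the name of the read-out). Against compound 1 `COC(=O)C1=C(C)NC(=O)NC1c1ccoc1`, which gives 42%, the step is a number 40 percentage points lower from compound 1 to compound 3 (beyond the scatter); against compound 2 `CC1=C(C(=O)C2CC2)C(c2ccoc2)NC(=O)N1`, which gives 10%, the step is a number 8 percentage points lower from compound 2 to compound 3 (within the scatter), so compound 3 stands beyond the scatter under compound 1 and within the scatter of compound 2. Compound 1 to compound 2 is a number 32 percentage points lower from compound 1 to compound 2 (beyond the scatter).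

Compound 4 `CC1=C(C(=O)NC(C)C)C(c2ccoc2)NC(=O)N1` differs from compound 3 by methyl in place of hydrogen on a saturated chain carbon bound to an amide-type nitrogen and a saturated chain carbon. Among the compounds with values here, no measured step changes a group on the ethylamino chain; the steps that bear on this part of the molecule all exchange the whole group on the carbonyl carbon, and of these only the two large drops from compound 1 are beyond the scatter, while the exchange of cyclopropyl for ethylamino stays within it. The small addition in compound 4 is therefore expected to give at most a step within the scatter in this assay, a number 4 percentage points higher from compound 3 to compound 4 (within the scatter), in no fixed direction. Compound 4 is estimated at 6%, ranging from 0% to 20%.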

Compound 4, a percentage reported as inhibition, at one concentration (the size of the read-out at that concentration, not a potency): 3%
Compound 4: the middle estimate sits 3 percentage points above what was measured, and the stated range covers the measured number.
By their numbers in this assay, from the lowest: compounds 3, 4 and 2 (each within the scatter of the next); then compound 1.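

Within the data shown here, the first change on the ethylamino chain itself, ethylamino to isopropylamino, leaves the result in this assay essentially unmoved, with a number 1 percentage points higher from compound 3 to compound 4 (within the scatter) as its step, so with the added methyl on this saturated chain carbon the number stays level at this low value, without any readable change. Exchanging the whole group on the carbonyl carbon gives the same picture for the new amide: a number 7 percentage points lower from compound 2 to compound 4 (within the scatter) stays within the scatter, while a number 39 percentage points lower from compound 1 to compound 4 (beyond the scatter) is a large drop and matches the earlier fall from methoxy to ethylamino, leaving compound 1 alone apart from the other three. Still open, going by these compounds, is whether ethoxy, dimethylamino or a longer chain on the carbonyl carbon would side with compound 1 or with the low group. No measured evidence bears on the reason for these differences.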